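Cytotoxicity notes: trifluoromethoxy to tert-butyl on the urea aryl

A few compounds are considered here, and "the series" means these few. Any claim that something is new, unique, unknown or untested is made for them only; others in the source may bear on it.

Measured in an ADME assay on HepG2 cells (Homo sapiens) for cytotoxicity, with a stated time of 72 h; on this read-out lower numbers stand for an effect already at smaller amounts and higher numbers for an effect only at larger amounts of compound:
Compound 1 `Cc1cc(NC(=O)Nc2ccc(F)c(F)c2)c2ccccc2n1` gives 21000 nM
Compound 2 `Cc1cc(NC(=O)Nc2ccccc2OC(F)(F)F)c2ccccc2n1` gives > 25000 nM, which is a limit of this assay and not a number
Compound 3 `Cc1cc(NC(=O)Nc2ccc(Cl)c(Cl)c2)c2ccccc2n1` gives 17000 nM

Compound 2 therefore stands at the limit of > 25000 nM in this assay, at which 1 of the 3 values shown sits, rather than at a measured point. Compound 4 `Cc1cc(NC(=O)Nc2ccccc2C(C)(C)C)c2ccccc2n1` is not yet measured; it differs from compound 2 as follows: tert-butyl in place of trifluoromethoxy on an aromatic carbon. Within the data shown here, no measured pair differing in one place is available in this set, so the step is estimated only from the change itself. The expected step that the limit leaves unreadable from compound 2 to compound 4 is none beyond the scatter. Compound 4 is estimated at 28000 nM, with a range from 12000 nM to 60000 nM, and a limit rather than a number is likely to be reported.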

Compound 4, half-maximal effective concentration: > 25000 nM
Compound 4 ended at the assay's limit (the forecaster's own chance of this, stated with the estimate: 55%); the middle value is on the limit's open side.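

Among these compounds, compound 2 and compound 4 both give a limit and not a number in this assay so no step between them can be read: the limit of > 25000 nM in this assay, at which 2 of the 4 values shown sit.

The compounds shown leave open whether tert-butyl in place of trifluoromethoxy changes this read-out at all.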